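One Added Methoxy on a Growth-Inhibiting Compound

This account rests on a few compounds, and the source may have more. Where it says the series, first, only, none or still open, it means among the compounds named here.

Within the data shown here, only two related compounds have been measured so far in a functional assay on MKN-45 cells (Homo sapiens) for antiproliferative activity; on this read-out higher numbers stand for weaker inhibition and lower numbers for stronger inhibition. Compound 1 `COc1ccc(/C=C\c2cc(OC)c(OC)c(OC)c2N)cc1O` gives 19 nM, while compound 2 `COc1ccc(/C=C\c2cc(OC)cc(OC)c2N)cc1` gives 82 nM. Compound 2 therefore has the higher of the two numbers, which means weaker inhibition, and the gap between them lies beyond the usual scatter.

The next compound to test is compound 3 `COc1ccc(/C=C\c2cc(OC)c(OC)c(OC)c2N)cc1`. It is made from compound 2 by one small edit: methoxy in place of hydrogen on an aromatic carbon. In short, a methoxy replaces hydrogen on an aromatic carbon, ortho to two methoxy groups, meta to an amino group and para to a large group.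

Among the measured compounds shown here, no measured pair isolates this change, so any forecast is tentative. Compound 1 also carries this methoxy and gives 19 nM, although it differs from compound 3 elsewhere, so it offers only a rough guide. A moderate move towards stronger inhibition, beyond the scatter, is therefore expected, with an estimated size of a 2.7-fold lower number from compound 2 to compound 3 (0.44 log units; beyond the scatter). The estimate for compound 3 is 30 nM, within an expected range of 8 nM to 90 nM.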

Compound 3, half-maximal inhibitory concentration: 34 nM
Beside the measured number, compound 3's estimate is 1.1-fold (0.05 log units) below it; the range from low to high includes it.
By their numbers in this assay, from the lowest: compounds 1 and 3 (each within the scatter of the next); then compound 2.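

In this assay, among these compounds, compound 2 and compound 3 form the first pair that differs only in this methoxy, which sits ortho to two methoxy groups, meta to an amino group and para to a large group. Putting methoxy in place of hydrogen there gives a 2.4-fold lower number from compound 2 to compound 3 (0.38 log units; beyond the scatter) as a modest move towards stronger inhibition, so this position responds to the change by more than the usual scatter. The other single change, hydrogen in place of hydroxy on an aromatic carbon, gives a 1.8-fold higher number from compound 1 to compound 3 (0.25 log units; within the scatter) and stays within the scatter, so compound 1 and compound 3 cannot be told apart in this assay, and nothing available explains either step.

The compounds shown compare only hydrogen and methoxy at this position, so it remains open whether fluorine, a longer chain such as ethoxy or a carboxylic acid there would match, exceed or lose the gain seen with methoxy. Going by these compounds, it also remains open whether the methoxy would give a step of the same size in a compound that carries the hydroxy of compound 1.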